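The source may hold more compounds than are shown below. What is called first, only, known or untested is meant among the compounds shown, and "the series" means these compounds.

Measured compounds:
Compound 1, `COc1ccc(-c2nc3cc(C)ccn3c2Nc2cc(OC)c(OC)c(OC)c2)cc1O`, gives 48000 nM.
Compound 2, `COc1cc(Nc2c(-c3cccc(O)c3)nc3cnccn23)cc(OC)c1OC`, gives 63000 nM.

Both values come from an ADME assay on Vero cells (Chlorocebus sabaeus) for cytotoxicity, read by MTT assay; on this read-out higher numbers stand for lower toxicity in this test and lower numbers for higher toxicity in this test. Compound 2 holds the highest of the two numbers, yet compound 1 sits within the usual scatter of it, so the two values show no real difference between them in this assay.

Compound 3, `COc1cc(-c2nc3cnccn3c2Nc2cc(OC)c(OC)c(OC)c2)cc(OC)c1O`, has not been measured. Its structure differs from compound 2 in one place: 4-hydroxy-3,5-dimethoxyphenyl in place of 3-hydroxyphenyl on an aromatic carbon. Among the compounds with values here, no measured pair shows what such a change does in this assay, so there is no measured step to build on. With both known numbers lying close together, the change is expected to move the number little, if at all, beyond the scatter, as the step of a 1.1-fold lower number from compound 2 to compound 3 (0.06 log units; within the scatter) conveys. Compound 3 is therefore expected to give 55000 nM, within a range from 25000 nM to 120000 nM.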

Compound 3, concentration lethal to 50% of the cells: 62000 nM
Estimate against measurement, compound 3: 1.1-fold (0.05 log units) below; the range from low to high includes it.
By their numbers in this assay, from the lowest: compounds 1, 3 and 2 (each within the scatter of the next).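

The earlier compounds shown here offered no comparison of a single change, and this pair supplies one in this assay. On the aromatic carbon of the five-membered ring with 2 nitrogen, 4-hydroxy-3,5-dimethoxyphenyl in place of 3-hydroxyphenyl gives a 1.0-fold lower number from compound 2 to compound 3 (0.01 log units; within the scatter) even though the entering group has 11 heavy atoms instead of 7 and 3 hydrogen-bond acceptors instead of 1, while both groups keep 1 hydrogen-bond donor. No measurement at hand explains why the two groups read alike.

Both groups are hydroxylated phenyl rings, so this single pair cannot show whether the same holds for a different kind of group at this place, such as a plain phenyl ring or a ring carrying an amine or a carboxylic acid. It also leaves open whether the same change would read alike on another core.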